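Aryl group variation on the shared core: measured set and next step

The source may report more compounds than this note shows. Statements on the series, on what has been measured and on what is new or still open speak of the compounds shown alone.

Measured so far in a functional assay on MCF7 cells (Homo sapiens) for inhibition, read by CCK-8 assay, with a stated time of 48 h; on this read-out lower numbers stand for stronger inhibition and higher numbers for weaker inhibition:
compound 1 `COc1ccc(-c2cc3nccc(-c4cc(OC)c(OC)c(OC)c4)n3n2)cc1N` gives 27 nM
compound 2 `COc1cc(-c2ccnc3cc(-c4ccc5cc[nH]c5c4)nn23)cc(OC)c1OC` gives 23 nM
compound 3 `COc1cc(-c2ccnc3cc(-c4c[nH]c5ccccc45)nn23)cc(OC)c1OC` gives 85 nM

Compound 3 stands at the highest number of the three. The two steps that reach it are a 3.1-fold higher number from compound 1 to compound 3 (0.50 log units; beyond the scatter) and a 3.7-fold higher number from compound 2 to compound 3 (0.57 log units; beyond the scatter), both beyond the scatter; compounds 1 and 2 sit within the scatter of each other a 1.2-fold lower number from compound 1 to compound 2 (0.07 log units; within the scatter).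

Compound 4 `COc1cc(-c2ccnc3cc(-c4ccccc4)nn23)cc(OC)c1OC` is the next step from compound 3: phenyl in place of 1H-indol-3-yl on an aromatic carbon. Phenyl has no precedent in the measured set, so no step bears directly on it. The two steps into compound 3 show only that 1H-indol-3-yl carries the highest number of the three aryl groups tried. Whether phenyl behaves like the other aryl groups or like 1H-indol-3-yl cannot be read from the data, so the expected step of a 1.3-fold higher number from compound 3 to compound 4 (0.11 log units; within the scatter) is wide, centred near no change beyond the scatter. Compound 4 is estimated at 110 nM, with a range from 30 nM to 450 nM.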

Compound 4, half-maximal inhibitory concentration: 254 nM
For compound 4 the middle estimate is 2.3-fold (0.36 log units) below the measured one; low and high end bracket the measured number.
By their numbers in this assay, from the lowest: compounds 2 and 1 (each within the scatter of the next); then compound 3; then compound 4.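

In this assay, phenyl on this aromatic carbon of the five-membered ring gives the weakest compound of the four, with a 3.0-fold higher number from compound 3 to compound 4 (0.48 log units; beyond the scatter), an 11-fold higher number from compound 2 to compound 4 (1.04 log units; beyond the scatter) and a 9.4-fold higher number from compound 1 to compound 4 (0.97 log units; beyond the scatter). The earlier compounds shown here compared only decorated aryl groups; compound 4 adds an undecorated reference, and 3-amino-4-methoxyphenyl, 1H-indol-6-yl and 1H-indol-3-yl all give lower numbers than phenyl. No measured evidence on the series accounts for these steps.

The compounds shown leave open how the amino group and the methoxy group of compound 1 each stand on a phenyl ring alone, since both differ from compound 4 together. Also open, as far as these compounds go, is how a phenyl ring carrying a hydroxyl group or a carboxylic acid would stand at this position.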